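The source may hold more compounds than are shown below. What is called first, only, known or untested is meant among the compounds shown, and "the series" means these compounds.

Measured compounds in a functional assay on PC-3 cells (Homo sapiens) for cytotoxicity, with a stated time of 48 h; on this read-out higher numbers stand for weaker inhibition and lower numbers for stronger inhibition:
- compound 1, `O=[N+]([O-])c1ccc(CN2CCC(n3cc(CC(OCc4cc(-c5ccc(Br)cc5)no4)c4ccc(Br)cc4)nn3)CC2)cc1`, gives > 25000 nM, a limit of the assay.
- compound 2, `N#Cc1ccc(-c2cc(COC(Cc3cn(C4CCN(Cc5ccc([N+](=O)[O-])cc5)CC4)nn3)c3ccc(Br)cc3)on2)cc1`, gives 2000 nM.
- compound 3, `O=[N+]([O-])c1ccc(CN2CCC(n3cc(CC(OCc4cc(-c5cccc(Br)c5)no4)c4ccc(Br)cc4)nn3)CC2)cc1`, gives > 25000 nM, again a limit of the assay.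

Compound 3 thus stands at the limit, as the limit of > 25000 nM in this assay, at which 2 of the 3 values shown sit, notes; of the three values shown, only compound 2 is a number. Within the series, the step of an at least 12-fold lower number from compound 1 to compound 2 (1.09 log units; beyond the scatter) and the reverse-reading step an at least 12-fold higher number from compound 2 to compound 3 (1.09 log units; beyond the scatter) both show that the 4-cyanophenyl analogue alone gives a readable number. The step that the two limits leave unreadable from compound 1 to compound 3 compares the two limit-bound compounds directly.

Compound 4, `O=[N+]([O-])c1ccc(CN2CCC(n3cc(CC(OCc4cc(-c5cccc(F)c5)no4)c4ccc(Br)cc4)nn3)CC2)cc1`, differs from compound 3 in one place: fluoro in place of bromo on an aromatic carbon. Among the compounds with values here, no measured step follows a bromo-to-fluoro exchange on this ring; the only exchange at this position that is measured, bromo to cyano in the 4-position, is the step from compound 1 to compound 2. The step from compound 3 to compound 4 keeps a halogen in the 3-position, and the measured halogen-bearing compounds 1 and 3 both sit at the limit.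

Compound 4 is therefore expected to remain at or near the limit, with an estimated value of 25000 nM (range 8000 nM to 60000 nM), corresponding to an expected step of a number no higher from compound 3 to compound 4 (the limit leaves the size open).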

Compound 4, half-maximal inhibitory concentration: 9000 nM
Compound 4: the middle estimate sits 2.8-fold (0.44 log units) above what was measured; the measured number falls inside the stated range.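

In this assay, replacing bromo with fluoro on this ring gives an at least 2.7-fold lower number from compound 3 to compound 4 (0.44 log units; beyond the scatter), so a halogen at this position does not by itself leave a compound at the limit, and the identity of the halogen matters here. The 4-cyanophenyl group still gives the lower number, with a 4.5-fold higher number from compound 2 to compound 4 (0.65 log units; beyond the scatter), but a readable value in this set no longer depends on the nitrile alone. The 3-fluorophenyl group also reads lower than the 4-bromophenyl group, with an at least 2.7-fold lower number from compound 1 to compound 4 (0.44 log units; beyond the scatter), and the true size of this step and of the step from the 3-bromophenyl compound stays open, as both start from a limit: the limit of > 25000 nM in this assay, at which 2 of the 4 values shown sit.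

The step between the two bromo compounds cannot be read, which leaves the effect of the halogen's place on the ring unresolved. From the compounds shown here alone, how an amine, a methoxy group or a plain hydrogen in place of the fluoro would read in this assay also stays open.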